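Series notes: hydroxyaryl tail variants on the shared imide core

This account rests on a few compounds, and the source may have more. Where it says the series, first, only, none or still open, it means among the compounds named here.

Measured so far in an assay on isolated protein for inhibition of lysosomal alpha-glucosidase (Rattus norvegicus), read by colorimetric assay; on this read-out higher numbers stand for weaker inhibition and lower numbers for stronger inhibition:
- compound 1 `Cc1ccc(S(=O)(=O)Nc2ccc3c(c2)C(=O)N(CCNc2ccc(O)c(O)c2)C3=O)cc1` gives 28800 nM
- compound 2 `Cc1ccc(S(=O)(=O)Nc2ccc3c(c2)C(=O)N(Cc2ccccc2F)C3=O)cc1` gives 195000 nM
- compound 3 `Cc1ccc(S(=O)(=O)Nc2ccc3c(c2)C(=O)N(CCNc2ccccc2)C3=O)cc1` gives 99600 nM

Compound 3 stands second highest of the three numbers; its nearest neighbour is compound 2, and the gap between them is within the scatter, so no order between compound 2 and compound 3 is claimed. Compound 1 sits further off and is the lowest number of the set.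

Compound 4 `Cc1ccc(S(=O)(=O)Nc2ccc3c(c2)C(=O)N(CCOc2cccc(O)c2)C3=O)cc1` is not yet measured. It differs from compound 3 by 3-hydroxyphenoxy in place of anilino on a saturated chain carbon, two bonds along the chain from an amide-type nitrogen in a ring.

Within the data shown here, two measured steps bear on this. The step of a 3.5-fold higher number from compound 1 to compound 3 (0.54 log units; beyond the scatter) shows that taking away the two hydroxyl groups on the aryl tail raised the number by a modest amount, beyond the scatter. The step of a 2.0-fold lower number from compound 2 to compound 3 (0.29 log units; within the scatter) shows that swapping the whole tail between an arylmethyl and an anilinoethyl arrangement stayed within the scatter. Compound 4 restores one hydroxyl on the tail, now through an oxygen rather than an amine link, so a modest move back toward a lower number is expected, smaller than the step from compound 1 to compound 3 because compound 1 with 28800 nM carries two hydroxyls. The expected step is a 1.8-fold lower number from compound 3 to compound 4 (0.26 log units; within the scatter). Compound 4 is therefore estimated at 55000 nM, with a range from 22000 nM to 140000 nM.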

Compound 4, half-maximal inhibitory concentration: 55600 nM
Compound 4: the middle estimate sits 1.0-fold (0.00 log units) below what was measured; measured number inside the range.
By their numbers in this assay, from the lowest: compounds 1, 4, 3 and 2 (each within the scatter of the next, the first and the last beyond it).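

In this assay, the 3-hydroxyphenoxy tail, linked through oxygen, can stand at this chain position without a change that clears the scatter, either against the anilino tail (a 1.8-fold lower number from compound 3 to compound 4 (0.25 log units; within the scatter)) or against the (3,4-dihydroxyphenyl)amino tail (a 1.9-fold higher number from compound 1 to compound 4 (0.29 log units; within the scatter)). Against the 2-fluorophenyl compound the step does clear the scatter (a 3.5-fold lower number from compound 2 to compound 4 (0.54 log units; beyond the scatter)), so a nitrogen in the tail is not needed for a separation from compound 2 that compound 3 did not show. No measured evidence bears on why these tails compare as they do.

The oxygen link and the hydroxyl changed together in compound 4, so their separate contributions stay unresolved. Also open, on these data alone, is what an unsubstituted phenoxy tail, a carboxylic acid in place of the hydroxyl, or a longer chain would give.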